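This account rests on a few compounds, and the source may have more. Where it says the series, first, only, none or still open, it means among the compounds named here.

Compound 1 `OCC1CCN(c2nccnc2Oc2ccc(Nc3nc4ccccc4s3)cc2)CC1`; compound 2 `OC1CN(c2nccnc2OC2CN(c3ccc4ccccc4n3)C2)C1`; compound 3 `c1ccc(-c2nccnc2OC2CN(c3ccc4ccccc4n3)C2)cc1`; compound 4 `c1ccc2nc(N3CC(Oc4nccnc4-c4ccncc4)C3)ccc2c1`, not yet measured.

In a physicochemical assay for solubility, in phosphate buffer, at pH 7.4 (a higher number here means a more soluble compound, a lower number a less soluble compound), compound 1 gives 6000 nM. Compound 2 gives 41000 nM, the highest of the two numbers, with compound 1 standing clearly lower. For compound 3 this assay reports only a limit, < 1000 nM, which is the limit of < 1000 nM in this assay, at which 1 of the 3 values shown sits. Compound 4 differs from compound 2 in one place: pyridin-4-yl in place of 3-hydroxyazetidin-1-yl on an aromatic carbon. For the measured compounds named here, the one measured step that bears on this is an at least 41-fold lower number from compound 2 to compound 3 (1.61 log units; beyond the scatter), where a different aromatic ring replaced the same group. A drop of the same kind is therefore expected for compound 4, though perhaps a smaller one, and the estimate is 2500 nM, within 700 nM to 8000 nM. For compound 4 this means an expected step of a 16-fold lower number from compound 2 to compound 4 (1.21 log units; beyond the scatter).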

Compound 4, solubility: 56000 nM
For compound 4 the middle estimate is 22-fold (1.35 log units) below the measured one; measured number above the stated range.
By their numbers in this assay, from the lowest: compound 1; then compounds 2 and 4 (each within the scatter of the next). At a limit, below all of these: compound 3.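

In this assay, an aromatic ring at this position does not by itself bring the number down: pyridin-4-yl in place of phenyl gives an at least 56-fold higher number from compound 3 to compound 4 (1.74 log units; beyond the scatter). Pyridin-4-yl in place of 3-hydroxyazetidin-1-yl gives a 1.4-fold higher number from compound 2 to compound 4 (0.14 log units; within the scatter), so on this aromatic carbon the two groups cannot be told apart in this measurement. The first of these steps starts from compound 3, whose value is only a limit: the limit of < 1000 nM in this assay, at which 1 of the 4 values shown sits.

As far as these compounds go, it stays open whether pyridin-3-yl or pyridin-2-yl would behave like pyridin-4-yl or like phenyl. From the compounds shown here alone, it is also open whether a simple amine here would match 3-hydroxyazetidin-1-yl.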